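This account rests on a few compounds, and the source may have more. Where it says the series, first, only, none or still open, it means among the compounds named here.

Measured so far:
- compound 1, `CCN(C/C=C/C#CC(C)(C)C)Cc1cccc(OC[Si](C)(C)c2ccc(Cl)cc2)c1`: 400 nM
- compound 2, `CCN(C/C=C/C#CC(C)(C)C)Cc1cccc(OC[Si](C)(C)CCc2ccccc2)c1`: > 10000 nM

For the measured compounds named here, compound 1, with a 4-chlorophenyl on the silicon, gives 400 nM in a functional assay on liver (Sus scrofa) for inhibition of squalene monooxygenase (Homo sapiens), using microsomes (a lower number here means a stronger inhibitor, a higher number a weaker inhibitor), and holds the only numerical value in this set. Compound 2 returns only a limit in this assay, > 10000 nM, not a number. Going by the values given here, the one measured step is an at least 25-fold higher number from compound 1 to compound 2 (1.39 log units; beyond the scatter); it rests on (the limit of > 10000 nM in this assay, at which 1 of the 2 values shown sits).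

The unmeasured compound 3 is `CCN(C/C=C/C#CC(C)(C)C)Cc1cccc(OC[Si](C)(C)C2CCCCC2)c1`. It differs from compound 1 by cyclohexyl in place of 4-chlorophenyl on a silicon. Among the compounds with values here, only the step from compound 1 to compound 2 bears on this; it shows that leaving the 4-chlorophenyl for a phenethyl costs a large amount in this assay. The cyclohexyl keeps a six-membered ring directly on the silicon but gives up the aromatic character and the chlorine, so a loss is expected, though smaller than for the phenethyl change. The estimated step is a 6.3-fold higher number from compound 1 to compound 3 (0.80 log units; beyond the scatter), upward in this assay. Compound 3 is expected to give 2500 nM, with a range from 700 nM to 9000 nM.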

Compound 3, half-maximal inhibitory concentration: 20000 nM
Beside the measured number, compound 3's estimate is 8.0-fold (0.90 log units) below it; the whole stated range lies below it.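

In this assay, cyclohexyl on the silicon does not keep the level of the 4-chlorophenyl, with a 50-fold higher number from compound 1 to compound 3 (1.70 log units; beyond the scatter). A six-membered ring of carbon on the silicon is therefore not sufficient in itself: the change from 4-chlorophenyl to cyclohexyl replaces an aromatic ring with a non-aromatic one and removes the chlorine, and compound 1 stays the only compound shown with a value under the limit of this series, while both replacements shown, phenethyl and cyclohexyl, give higher numbers, with no compound here going against that. Phenethyl and cyclohexyl cannot be ranked against each other, because the step between the two compounds that carry them cannot be read: the limit of > 10000 nM in this assay, at which 1 of the 3 values shown sits.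

Still open, on these data alone, is whether the aromatic ring or the chlorine accounts for the difference, a question that a plain phenyl on the silicon would separate. Also open, as far as these compounds go, is how a 4-fluorophenyl, a 4-methoxyphenyl or a pyridyl ring at this place would compare, and whether any group there gives a lower number than compound 1 with its 400 nM.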